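From 3-methoxyphenyl to 4-isopropoxyphenyl in HepG2 cells

This account rests on a few compounds, and the source may have more. Where it says the series, first, only, none or still open, it means among the compounds named here.

Three compounds have been measured in a functional assay on HepG2 cells (Homo sapiens) for antiproliferative activity, read by MTT assay, with a stated time of 48 h; a higher number here means a weaker inhibitor, a lower number a stronger inhibitor:

Compound 1 `CCCCc1ccc2c(c1)C(=O)C(=O)N2`: > 10000 nM (a limit of the assay, not a number)
Compound 2 `COc1ccc(-c2ccc3c(c2)C(=O)C(=O)N3Cc2ccc(Br)cc2)cc1`: 700 nM
Compound 3 `COc1ccc(CN2C(=O)C(=O)c3cc(-c4cccc(OC)c4)ccc32)cc1`: 1890 nM

Compound 1 is reported only as the limit > 10000 nM. Compound 3 gives 1890 nM, the higher of the two actual numbers, and compound 2 gives 700 nM, a gap that lies beyond the scatter. Compound 3 is therefore the weaker of the two inhibitors with a measured number.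

The next compound, compound 4 `COc1ccc(CN2C(=O)C(=O)c3cc(-c4ccc(OC(C)C)cc4)ccc32)cc1`, carries 4-isopropoxyphenyl in place of the 3-methoxyphenyl of compound 3, on an aromatic carbon (4-isopropoxyphenyl in place of 3-methoxyphenyl on an aromatic carbon). Going by the values given here, no measured pair isolates this change, so any expectation is tentative. Among the compounds with values here, the only guide is compound 2 at 700 nM, which differs from compound 3 in more than one place. This leans the expectation slightly downward in this assay, towards a stronger inhibitor, but not clearly beyond the scatter. The expected change is estimated as a 1.6-fold lower number from compound 3 to compound 4 (0.20 log units; within the scatter). Compound 4 is expected to give 1200 nM, with an estimated range of 400 nM to 4000 nM.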

Compound 4, half-maximal inhibitory concentration: > 10000 nM
Compound 4: a limit, no number; the forecaster's own chance of this, stated with the estimate: 5%; at least 8.3-fold (0.92 log units) between middle value and limit.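

Going by these compounds alone, the swap of 3-methoxyphenyl for 4-isopropoxyphenyl, on an aromatic carbon of the shared core, is the first change here that can be read in a single place, and in this assay it gives an at least 5.2-fold higher number from compound 3 to compound 4 (0.72 log units; beyond the scatter). In this assay compound 4 gives > 10000 nM, which is a limit and not a number, so the step fixes only a lower bound on the change and not its full size: the limit of > 10000 nM in this assay, at which 2 of the 4 values shown sit. This position is therefore not indifferent to the aryl group it carries, as on the same core 3-methoxyphenyl leaves a measurable number while 4-isopropoxyphenyl does not.

The step alters both the place of the oxygen on the phenyl ring and the alkyl group attached to that oxygen, and the compounds shown do not separate the two; a 3-isopropoxyphenyl group on this core would do so. As far as these compounds go, whether a small amine or a carboxylic acid on that phenyl ring would keep a measurable number in this assay also remains open.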